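The source may report more compounds than this note shows. Statements on the series, on what has been measured and on what is new or still open speak of the compounds shown alone.

Compound 1 `COc1ccc2[nH]c(C(=O)N3CC(=O)N(Cc4ccccc4)[C@@H](CCc4ccccc4)C3)cc2c1` gives 4400 nM in a physicochemical assay for solubility, read by spectrophotometry, in phosphate buffer, with a stated time of 2 h, at pH 7.4 (a higher number here means a more soluble compound, a lower number a less soluble compound), the lowest of the three numbers in hand. Compound 3 `COc1cccc(CN2C(=O)CN(C(=O)c3cc4cc(OC)ccc4[nH]3)C[C@@H]2CCc2ccccc2)c1` gives 5100 nM, and the step of a 1.2-fold higher number from compound 1 to compound 3 (0.06 log units; within the scatter) is within the scatter. Going by the values given here, compound 2 `COc1ccc2[nH]c(C(=O)N3CC(=O)N(Cc4cccc(OC(F)F)c4)[C@@H](CN4CCC(C#N)CC4)C3)cc2c1` gives 27900 nM; it differs from compound 1 in several places at once, so no single step to it is computed. Compound 4 `COc1ccc2[nH]c(C(=O)N3CC(=O)N(Cc4ccccc4)[C@@H](COC(C)(C)C)C3)cc2c1` differs from compound 1 by tert-butoxy in place of benzyl on a saturated chain carbon bound to a saturated ring carbon. Among the compounds with values here, none of the measured steps touches this chain carbon: the one single step, a 1.2-fold higher number from compound 1 to compound 3 (0.06 log units; within the scatter), concerns a methoxy on an aromatic carbon and stays within the scatter. The expected step of a 1.4-fold higher number from compound 1 to compound 4 (0.13 log units; within the scatter) is therefore small and carries wide uncertainty. For compound 4 the estimate is 6000 nM, in the range 2000 nM to 20000 nM.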

Compound 4, solubility: 65500 nM
Beside the measured number, compound 4's estimate is 11-fold (1.04 log units) below it; measured number outside the range, above it.
By their numbers in this assay, from the lowest: compounds 1 and 3 (each within the scatter of the next); then compound 2; then compound 4.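

In this assay, the saturated chain carbon bound to a saturated ring carbon proves to be a sensitive position: tert-butoxy in place of benzyl gives a 15-fold higher number from compound 1 to compound 4 (1.17 log units; beyond the scatter). The only earlier single step, a 1.2-fold higher number from compound 1 to compound 3 (0.06 log units; within the scatter), concerned an aromatic carbon and stayed within the scatter, so this is the first single change shown to move the read-out beyond it. No available measurement explains the size of this step. The change removes the aromatic ring and brings in the ether oxygen together, leaving open which of the two carries the step. Going by these compounds, how a hydroxyl or a carboxylic acid on this chain would read also remains open.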